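A few compounds are considered here, and "the series" means these few. Any claim that something is new, unique, unknown or untested is made for them only; others in the source may bear on it.

Measured compounds:
- compound 1, `NS(=O)(=O)c1ccc(N2N=C(c3ccc(Oc4ccccc4)cc3)CC2c2ccccc2F)cc1`, gives 96000 nM
- compound 2, `NS(=O)(=O)c1ccc(N2N=C(c3ccc(Oc4ccccc4)cc3)CC2c2ccccc2)cc1`, gives 85000 nM
- compound 3, `Cc1ccccc1C1CC(c2ccc(Oc3ccccc3)cc2)=NN1c1ccc(S(N)(=O)=O)cc1`, gives 90000 nM

In an ADME assay on Vero 76 cells (Chlorocebus sabaeus) for cytotoxicity, read by MTT assay, with a stated time of 96 h (on this read-out lower numbers stand for higher toxicity in this test and higher numbers for lower toxicity in this test), compound 3 gives 90000 nM, the second highest of the three numbers. Its neighbours sit close: a 1.1-fold higher number from compound 2 to compound 3 (0.02 log units; within the scatter) and a 1.1-fold lower number from compound 1 to compound 3 (0.03 log units; within the scatter), so the three compounds are indistinguishable on this read-out.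

Compound 4, `Cc1ccccc1C1CC(c2ccccc2)=NN1c1ccc(S(N)(=O)=O)cc1`, differs from compound 3 in one place: hydrogen in place of phenoxy on an aromatic carbon. For the measured compounds named here, no measured step matches this change. The measured steps each swap a small group on a different ring, fluoro, hydrogen or methyl, and every one of them stayed within the scatter. Going by the values given here, how the phenoxy group affects this assay is therefore unknown from these data, and the only guide is that the three measured numbers all lie close together. On that basis the expected step is no change at the digits printed from compound 3 to compound 4 (within the scatter), meaning no change beyond the scatter. Compound 4 is therefore estimated at 90000 nM, with a range of 40000 nM to 200000 nM.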

Compound 4, half-maximal cytotoxic concentration: 24000 nM
Compound 4: middle estimate off by 3.8-fold (0.57 log units), on the high side; the whole stated range lies above it.
By their numbers in this assay, from the lowest: compound 4; then compounds 2, 3 and 1 (each within the scatter of the next).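

In this assay, replacing phenoxy with hydrogen is the first change among these compounds to move the number beyond the scatter, giving a 3.8-fold lower number from compound 3 to compound 4 (0.57 log units; beyond the scatter). Swaps among fluoro, hydrogen and methyl on the other ring left the number within the scatter, whereas this aromatic carbon clearly matters: here, removing phenoxy goes with higher toxicity in this test. Nothing in the available data explains this shift.

On these data alone, it remains open whether a methoxy or benzyloxy group on this carbon would give a number closer to that of compound 3 or that of compound 4. As far as these compounds go, it is also open whether removing phenoxy would have a similar effect with hydrogen or fluoro, rather than methyl, on the other ring.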